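Tolerance on Blood Cells Across a Change of Aryl Ether

The compounds below may be only part of what the source reports. "The series", "measured", "known", "first", "only" and "open" are said of these compounds alone.

Compound 1, `CC(CCNC(=O)c1c(Cl)cncc1Cl)N1CCC(C(Oc2ncccc2Cl)c2ccc(C(F)(F)F)cc2)CC1`, is the starting point. In an ADME assay on PBMC cells (Homo sapiens) for cytotoxicity (a higher number here means that more compound is tolerated, a lower number that less compound is tolerated), compound 1 gives 16700 nM, the lower of the two values recorded. Among the compounds with values here, the only other measured compound, compound 2, `CCO/N=C(/c1ccc(Br)cc1)C1CCN(C(C)CCNC(=O)c2c(Cl)cncc2Cl)CC1`, gives in this assay a value of 33800 nM, and this gap lies beyond the scatter of repeated runs. Within the data shown here, no pair differing in a single place has been measured, so no step size is known from experiment.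

Compound 3, `CC(CCNC(=O)c1c(Cl)cncc1Cl)N1CCC(C(Oc2cccc(C(F)(F)F)c2)c2ccc(C(F)(F)F)cc2)CC1`, has not yet been tested. It differs from compound 1 in one place: 3-(trifluoromethyl)phenyl in place of 3-chloropyridin-2-yl on an oxygen on a saturated carbon. The group that leaves carries one hydrogen-bond acceptor; the group that enters carries none, and both sit on an oxygen on a saturated carbon.

Among the measured compounds shown here, with no measured step to lean on, compound 3 is expected to lie close to compound 1, with at most a modest shift downward, as the estimated step of a 1.4-fold lower number from compound 1 to compound 3 (0.14 log units; within the scatter) expresses. The estimate for compound 3 in this assay is 12000 nM, within a range of 5000 nM to 30000 nM.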

Compound 3, half-maximal cytotoxic concentration: 7000 nM
Compound 3: middle estimate off by 1.7-fold (0.23 log units), on the high side; measured number inside the range.
By their numbers in this assay, from the lowest: compound 3; then compound 1; then compound 2.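

The step of a 2.4-fold lower number from compound 1 to compound 3 (0.38 log units; beyond the scatter) in this assay shows that the group on this oxygen on a saturated carbon is not silent: the change moves the number beyond the usual scatter, although the step remains modest. The exchange of 3-chloropyridin-2-yl for 3-(trifluoromethyl)phenyl alters several things at once, removing the ring nitrogen and the hydrogen-bond acceptor, replacing the chlorine with trifluoromethyl and adding heavy atoms, and this single step cannot separate them. Nothing available bears on why the number moves.

The compounds shown leave open whether the step follows the ring nitrogen or the substituent on the ring. A 3-chlorophenyl or a 3-(trifluoromethyl)pyridin-2-yl on the same oxygen would pull these two apart, and a plain phenyl would show how much either substituent matters here.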